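Moving the nitro group around the phenyl ring

The source may report more compounds than this note shows. Statements on the series, on what has been measured and on what is new or still open speak of the compounds shown alone.

Compound 2 `O=c1ccc2cc(OCc3cn(-c4ccc(Cl)c(Cl)c4)nn3)ccc2o1` carries a 3,4-dichlorophenyl on the triazole nitrogen of the shared core, but in a functional assay on COLO 205 cells (Homo sapiens) for cytotoxicity, read by MTT assay, with a stated time of 48 h (a higher number here means a weaker inhibitor, a lower number a stronger inhibitor), compound 2 has "not determined" (no result reported): no number was reported, so it stands nowhere on the scale. Compound 1 `O=c1ccc2cc(OCc3cn(-c4cccc([N+](=O)[O-])c4)nn3)ccc2o1`, a close relative with a 3-nitrophenyl in the same position, gives 36600 nM in this assay, a weak result. Compound 3 `O=c1ccc2cc(OCc3cn(-c4ccc([N+](=O)[O-])cc4)nn3)ccc2o1` arises from compound 2 by the change (4-nitrophenyl in place of 3,4-dichlorophenyl on an aromatic nitrogen). Among the compounds with values here, with no measured value for compound 2, no step can be computed, and the size and direction of the change in this assay can only be guessed. Compound 3 is expected to land close to where compound 1 sits with 36600 nM, since both bear a nitrophenyl, and so compound 3 is estimated at 30000 nM, with a range from 8000 nM to 100000 nM in this assay.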

Compound 3, half-maximal inhibitory concentration: 48700 nM
Compound 3: middle estimate off by 1.6-fold (0.21 log units), on the low side; measured number inside the range.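

In this assay, shifting the nitro group on the phenyl ring, with the shared core unchanged, gives a 1.3-fold higher number from compound 1 to compound 3 (0.12 log units; within the scatter), so the 3-nitrophenyl and 4-nitrophenyl groups on this aromatic nitrogen cannot be told apart, and the placement of the nitro group shows no measurable effect on this read-out. Compound 2 has no number, so the exchange of 3,4-dichlorophenyl for 4-nitrophenyl cannot be read, and nothing can be said about how a nitrophenyl compares with a chlorinated phenyl here. No measurement is available that would explain this result.

The compounds shown leave open whether any substituent at this position can move the value beyond the scatter. An amine or a carboxylic acid in place of the nitro group, or a benzyl group in place of the phenyl, remains an open case.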